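The compounds below may be only part of what the source reports. "The series", "measured", "known", "first", "only" and "open" are said of these compounds alone.

Of the compounds shown here, three built on one shared core have been tested in a functional assay on Right cardiac atrium for agonist activity at histamine H2 receptor (Cavia porcellus), with a stated time of 30 min, in the presence of a further agent that is not named here; on this read-out lower numbers stand for smaller maximal responses and higher numbers for larger maximal responses. Compound 1 `COc1ccc(C(C)NC(=O)/N=C(\N)NCCCc2sc(N)nc2C)cc1` gives 0.91, the largest maximal response of the three. Compound 3 `CCCCCNC(=O)/N=C(\N)NCCCc1sc(N)nc1C` gives 0.78, and compound 2 `Cc1nc(N)sc1CCCN/C(N)=N/C(=S)N[C@@H](C)c1ccccc1` gives 0.65; both of these sit beyond the usual scatter below compound 1. Compound 4 `Cc1nc(N)sc1CCCN/C(N)=N/C(=O)NC(C)c1cccc(F)c1` is still to be measured. It differs from compound 1 in one place: 3-fluorophenyl in place of 4-methoxyphenyl on a saturated chain carbon bound to an amide-type nitrogen and a saturated chain carbon. Going by the values given here, no two measured compounds differ from each other in only one place, so nothing here shows how such an exchange shifts the response. The exchange is a modest one, and the expected step is a number 0.060 lower from compound 1 to compound 4 (within the scatter), a change that stays within the scatter. Compound 4 is thus expected to give about 0.85, somewhere between 0.7 and 1.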

Compound 4, intrinsic activity: the largest response reached, as a fraction of the reference agonist's: 0.85
Beside the measured number, compound 4's estimate shows no gap at the digits printed; the measured number falls inside the stated range.
By their numbers in this assay, from the lowest: compound 2; then compounds 3, 4 and 1 (each within the scatter of the next, the first and the last beyond it).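

In this assay, going by these compounds alone, replacing 4-methoxyphenyl with 3-fluorophenyl gives the first comparison of compounds that differ in one place, and the step is a number 0.060 lower from compound 1 to compound 4 (within the scatter). At this position, then, one substituted phenyl group can take the place of the other with no change in maximal response that stands out from the scatter. Nothing measured here explains why the response holds. The exchange alters both the substituent and where it sits on the ring, so 3-methoxyphenyl or 4-fluorophenyl would be needed to separate those two changes. On these data alone, whether a non-aromatic group such as cyclohexyl is tolerated here also remains open.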